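The compounds below may be only part of what the source reports. "The series", "measured", "known", "first", "only" and "open" are said of these compounds alone.

For the measured compounds named here, compound 1 `O=S(=O)(Nc1cccc2c1CCCC2c1c[nH]cn1)C1CC1` is the only member of the pair for which an assay on isolated protein for binding affinity to Alpha-1D adrenergic receptor (Rattus norvegicus), read by radioligand binding (on this read-out lower numbers stand for stronger inhibition and higher numbers for weaker inhibition), returns a number: compound 1 gives 2690 nM in this assay. Compound 2 `CCS(=O)(=O)Nc1cccc2c1CCCC2CN` sits at a limit of this assay rather than at a number, reporting < 10000 nM, which is the limit of < 10000 nM in this assay, at which 1 of the 2 values shown sits. With one number and one limit, compound 1 is the sole fixed point of the series; nothing about a step between two measured values can be read from what is shown, and the two values of compound 1 and compound 2 are not compared here beyond that.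

Compound 3 `Nc1cccc2c1CCCC2c1c[nH]cn1` has not been measured in this assay. Compared with compound 1 the change is hydrogen in place of cyclopropylsulfonyl on a nitrogen on an aromatic ring.

Going by the values given here, no measured step of this sort exists, so the expected step size rests on the structural change alone. The expectation is that removing the cyclopropylsulfonyl shifts this assay toward weaker binding by a modest amount, from compound 1 to compound 3 as a 1.9-fold higher number from compound 1 to compound 3 (0.27 log units; within the scatter), possibly no further than the scatter. Compound 3 is estimated at 5000 nM, with a range from 1500 nM to 15000 nM in this assay.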

Compound 3, inhibition constant: 191 nM
Beside the measured number, compound 3's estimate is 26-fold (1.42 log units) above it, outside the stated range (below it).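

In this assay, hydrogen in place of cyclopropylsulfonyl on a nitrogen on an aromatic ring gives a 14-fold lower number from compound 1 to compound 3 (1.15 log units; beyond the scatter), the first step the series offers at this position. The position is therefore sensitive to what it carries, and in this pair the cyclopropylsulfonyl group is not needed for binding, since the plain amino form gives the lower number. The data shown give no cause for the size or direction of this step.

For the compounds shown here, compound 2 stands at a limit of this assay, < 10000 nM, not at a number, so no step involving it can be read. Going by these compounds, whether the step belongs to the sulfonyl as a whole or to its cyclopropyl part stays open, as does how far the position tolerates other groups: a methylsulfonyl, an acetyl amide or a methylamino group on the same nitrogen of the shared core would begin to separate these readings.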